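The source may hold more compounds than are shown below. What is called first, only, known or untested is meant among the compounds shown, and "the series" means these compounds.

The measurements come from a functional assay on RS4-11 cells (Homo sapiens) for inhibition, read by CCK-8 assay, with a stated time of 48 h; on this read-out lower numbers stand for stronger inhibition and higher numbers for weaker inhibition. Compound 1 `O=C(NCCNS(=O)(=O)c1ccc(-c2ccccc2Oc2ccc(O)c(O)c2)s1)Nc1cc(Cl)cc(Cl)c1` gives 4500 nM in this assay. Compound 2 `COc1ccc(Oc2ccccc2-c2ccsc2S(=O)(=O)N2CCN(C(=S)Nc3cc(C(F)(F)F)cc(C(F)(F)F)c3)CC2)cc1OC` returns only a limit of the assay, > 50000 nM, and not a number. Compound 3 `O=S(=O)(NCCNC(=S)Nc1ccc(Cl)cc1)c1ccc(-c2ccccc2OCc2ccccc2)s1` likewise returns only a limit, > 50000 nM. Compound 3 therefore stands at the limit of > 50000 nM in this assay, at which 2 of the 3 values shown sit; of the three values shown, only compound 1 carries a number, and compound 3 and compound 2 both sit at that limit. Among the measured compounds shown here, no two measured compounds differ in a single place, so no step between measured compounds can be read from these data.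

Compound 4 `O=[N+]([O-])c1ccc(NC(=S)NCCNS(=O)(=O)c2ccc(-c3ccccc3OCc3ccccc3)s2)cc1` is not yet measured. It differs from compound 3 in one spot: nitro in place of chloro on an aromatic carbon. The nitro takes the place of the chloro on an aromatic carbon of a six-membered aromatic ring of carbon only, para to a large group; seen one bond further out, a 4-chlorophenyl becomes a 4-nitrophenyl. Nothing measured here shows how such a swap moves this assay, so the expectation is a step of no size beyond the usual scatter, and compound 4 is expected to return only a limit as well. The step expected a number no higher from compound 3 to compound 4 (the limit leaves the size open) is estimated as essentially none. Compound 4 is estimated at 50000 nM, in a range from 15000 nM to 100000 nM.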

Compound 4, half-maximal inhibitory concentration: 11300 nM
Beside the measured number, compound 4's estimate is 4.4-fold (0.65 log units) above it, outside the stated range (below it).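

Among the compounds shown here, this is the first comparison between two compounds that differ in a single place, and for the swap of 4-chlorophenyl to 4-nitrophenyl, this assay shows an at least 4.4-fold lower number from compound 3 to compound 4 (0.64 log units; beyond the scatter). The group at this spot, on the six-membered aromatic ring and para to a large group, therefore matters: with the nitro in place, compound 4 gives a measurable 11300 nM, whereas the chloro compound reaches no number at all. The step can only be stated as a minimum, and its true size remains unknown, because compound 3 sits at a limit of the assay and not at a number: the limit of > 50000 nM in this assay, at which 2 of the 4 values shown sit.

From the compounds shown here alone, whether a nitrile, a methoxy group or an amine at this same spot would move the number in the same direction, or by a similar amount, remains open. Also open is whether this swap would have a similar effect on the other cores shown, as this single pair is the only evidence for it.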